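Piperidine amide in place of dimethylamide on a cyclohexyl core

A few compounds are considered here, and "the series" means these few. Any claim that something is new, unique, unknown or untested is made for them only; others in the source may bear on it.

Measured so far in a physicochemical assay for lipophilicity, read by HPLC, at pH 2; a higher number here means a more lipophilic compound, a lower number a more polar compound:
compound 1, `CN(C)C(=O)[C@H]1CCC[C@@H](c2cccc(-n3ncc(C(=O)O)c3C3CC3)c2)C1`, gives 1.7
compound 2, `O=C(O)c1cnn(-c2cccc(-c3cccc(C(=O)N4CCCCC4)c3F)c2)c1C1CC1`, gives 2.3
compound 3, `CN(C)C(=O)c1cccc(-c2cccc(-n3ncc(C(=O)O)c3C3CC3)c2)c1F`, gives 1.3

Compound 4, `O=C(O)c1cnn(-c2cccc([C@@H]3CCC[C@H](C(=O)N4CCCCC4)C3)c2)c1C1CC1`, has not yet been measured in this assay. It arises from compound 1 by the change (piperidin-1-yl in place of dimethylamino on a carbonyl carbon). The same kind of change has already been made once among the measured compounds, from compound 3 to compound 2, where it reads piperidin-1-yl in place of dimethylamino on a carbonyl carbon and gave a number 1.00 log units higher from compound 3 to compound 2 (beyond the scatter); there the place was a carbonyl carbon whose other neighbour is an aromatic carbon, whereas in compound 4 that neighbour is a saturated ring carbon. How the core of compound 1 differs from the core of compound 3 is not broken down here. Because of a number 1.00 log units higher from compound 3 to compound 2 (beyond the scatter), a step of about a number 1.00 log units higher from compound 1 to compound 4 (beyond the scatter) is expected for compound 4 as well. Compound 4 is therefore estimated at 2.7 in this assay, between 2.3 and 3.1.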

Compound 4, distribution coefficient: 2.7
The estimate for compound 4 equals the measured number at the digits printed, and the stated range covers the measured number.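

In this assay the change to piperidin-1-yl in place of dimethylamino on a carbonyl carbon gives a number 1.00 log units higher from compound 1 to compound 4 (beyond the scatter), and the same change gives a number 1.00 log units higher from compound 3 to compound 2 (beyond the scatter), so the step reads the same at the digits printed whether the carbonyl carbon's other neighbour is a saturated ring carbon or an aromatic carbon. This shows that the step carried over between these two cores, but two pairs do not show that it would hold on any other core. Nothing measured here explains the size of the step.

The compounds shown leave open whether a pyrrolidin-1-yl or morpholin-4-yl group on the same carbonyl carbon would behave alike on both cores. They also leave open whether the step would survive replacing the carboxylic acid with a tetrazole.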